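Compound 3 to Compound 4: An Expected Inhibition Value

This account rests on a few compounds, and the source may have more. Where it says the series, first, only, none or still open, it means among the compounds named here.

Measured compounds:
compound 1 `CCCn1c(SCc2cccc(OC)c2)nc2c1c(=O)[nH]c(=O)n2C`: 34.2%
compound 2 `Cn1cnc2c1c(=O)n(CC(=O)N1CCC(F)(F)CC1)c(=O)n2C`: 11.3%
compound 3 `Cn1cnc2c1c(=O)n(CC(=O)N1CCN(C(=O)OC(C)(C)C)CC1)c(=O)n2C`: 20%

These three compounds were tested in a functional assay on MGC-803 cells (Homo sapiens) for inhibition, read by MTT assay, with a stated time of 48 h, tested at 20 uM; on this read-out higher numbers stand for more inhibition at the one concentration tested (going by the name of the read-out) and lower numbers for less inhibition. Compound 3 stands second highest of the three numbers. Compound 2 gives 11.3%, a number within the scatter of compound 3, so the two cannot be told apart. Compound 1 gives 34.2%, which lies beyond the scatter above compound 3.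

Compound 4 `C=CC(=O)N1CCN(C(=O)Cn2c(=O)c3c(ncn3C)n(C)c2=O)CC1` has not yet been measured. It differs from compound 3 in one place: vinyl in place of tert-butoxy on a carbonyl carbon. For the measured compounds named here, no measured pair shares this change, so nothing shows its effect; the step is expected to stay within the scatter, with at most a small rise. For compound 4 the expected value is 24%, between 8% and 45%. This estimate means an expected step of a number 4 percentage points higher from compound 3 to compound 4 (within the scatter).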

Compound 4, a percentage reported as inhibition, at one concentration (the size of the read-out at that concentration, not a potency): 1.3%
Estimate against measurement, compound 4: 22.7 percentage points above, and the stated range ends above it.
By their numbers in this assay, from the lowest: compounds 4, 2 and 3 (each within the scatter of the next, the first and the last beyond it); then compound 1.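

In this assay, for the compounds shown here, putting vinyl in place of tert-butoxy on this carbonyl carbon gives a step of a number 18.7 percentage points lower from compound 3 to compound 4 (beyond the scatter), something no earlier pair could show. What sits at this position can therefore change the read-out by more than the usual scatter, and here vinyl goes with less inhibition. Nothing measured here accounts for this step.

As far as these compounds go, it remains open whether the drop follows the loss of tert-butoxy or the presence of the double bond. An ethyl group or a methoxy group on the same carbonyl carbon would help separate the two.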